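Acid series against inositol hexakisphosphate kinase 3: the next step

This account rests on a few compounds, and the source may have more. Where it says the series, first, only, none or still open, it means among the compounds named here.

Measured in an assay for inhibition of inositol hexakisphosphate kinase 3 (Homo sapiens), read by colorimetric assay, coupled enzyme assay and malachite green, with a stated time of 120 min, in the presence of a further agent that is not named here; a higher number here means a weaker inhibitor, a lower number a stronger inhibitor:
compound 1 `CN(C)C(=O)/C=C/c1ccc2noc(-c3ccccc3)c2c1` — > 100000 nM
compound 2 `O=C(O)/C=C/c1ccc2noc(-c3ccc(OC(F)(F)F)cc3)c2c1` — 8370 nM
compound 3 `O=C(O)c1ccc2noc(-c3ccc(Oc4ccccn4)cc3)c2c1` — 2060 nM

The value of compound 1 is a limit of the assay, not a number; compound 1 sits at the limit of > 100000 nM in this assay, at which 1 of the 3 values shown sits. Among the numbers shown, compound 3 gives the lowest one, and compound 2 gives a higher one; that gap lies beyond the scatter. Both carry a free acid, compound 1 does not.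

Compound 4 `O=C(O)c1ccc2noc(-c3ccc(NC(=O)c4ccncn4)cc3)c2c1` keeps the acid and the shared core of compound 3 and changes only the group on the far ring: ((pyrimidin-4-yl)carbonyl)amino in place of (pyridin-2-yl)oxy on an aromatic carbon. Among the compounds with values here, no pair of measured compounds separates this change, so its size has no measured precedent here. Within the data shown here, the new group brings an amide hydrogen and a second ring nitrogen, and the series so far gives no guide to either. A step of modest size in this assay, in either direction, is expected, with a small tilt toward a lower number.

Compound 4 is estimated at 1500 nM, within 300 nM to 8000 nM, which means an expected step of a 1.4-fold lower number from compound 3 to compound 4 (0.14 log units; within the scatter).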

Compound 4, half-maximal inhibitory concentration: 430 nM
For compound 4 the middle estimate is 3.5-fold (0.54 log units) above the measured one, and the stated range covers the measured number.
By their numbers in this assay, from the lowest: compound 4; then compound 3; then compound 2. At a limit, above all of these: compound 1.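

In this assay, replacing (pyridin-2-yl)oxy with ((pyrimidin-4-yl)carbonyl)amino on an aromatic carbon, para to a large group, gives a 4.8-fold lower number from compound 3 to compound 4 (0.68 log units; beyond the scatter). Within the data shown here, this is the only measured step here between compounds that differ in one place, and it shows that the number responds to the group at this position when the acid and the shared core stay fixed. The change alters the linking atoms and the far ring together, and nothing measured here assigns the step to either part.

The compounds shown leave open whether the gain depends on the amide hydrogen or the second ring nitrogen; a methyl on the amide nitrogen, or a phenyl ring in place of pyrimidin-4-yl, would separate the two. They also leave open how far the carboxylic acid of compound 4 can be replaced, for example by a methyl ester or a primary amide.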